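Trimming an ethyl group to methyl

The source may report more compounds than this note shows. Statements on the series, on what has been measured and on what is new or still open speak of the compounds shown alone.

Compound 1 `CC(=O)N[C@@H]1CCCc2c1cncc2N1C(=O)c2ccc(Cl)cc2[C@H]1C` gives 43.5 mL/min/kg 
Compound 2 `CCC(=O)N[C@@H]1CCCc2c1cncc2N1C(=O)c2ccc(Cl)cc2[C@H]1CC` gives 44.9 mL/min/kg 

Clearance tells how quickly a compound is removed, so a low number means that it lasts longer. In an ADME assay on microsomes from liver (Mus musculus) for metabolic stability, read by LC-MS, using NADPH, with stated times of 10 min and 30 min (on this read-out higher numbers stand for fast clearance and lower numbers for slow clearance), compound 2 gives 44.9 mL/min/kg and compound 1 gives 43.5 mL/min/kg so these two compounds lie within the usual scatter of each other. Repeated measurements of one compound can differ this much, and the two numbers cannot be told apart.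

Compound 3 `CCC(=O)N[C@@H]1CCCc2c1cncc2N1C(=O)c2ccc(Cl)cc2[C@H]1C` has not been measured yet. It differs from compound 2 in one place hydrogen in place of methyl on a saturated chain carbon bound to a saturated ring carbon, which turns ethyl into methyl. For the measured compounds named here, no two measured compounds differ in just one place, so the data do not show what this change does by itself. Going by the values given here, the only guide is that compound 1 at 43.5 mL/min/kg and compound 2 at 44.9 mL/min/kg sit within the scatter, so no step beyond the scatter is expected in this assay here. The expected step is small, a 1.0-fold lower number from compound 2 to compound 3 (0.02 log units; within the scatter) and inside the scatter. Compound 3 is estimated at 43 mL/min/kg with an expected range from 25 mL/min/kg to 75 mL/min/kg around that figure.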

Compound 3, clearance: 45.6 mL/min/kg
For compound 3 the middle estimate is 1.1-fold (0.03 log units) below the measured one; the measured number falls inside the stated range.
By their numbers in this assay, from the lowest: compounds 1, 2 and 3 (each within the scatter of the next).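

In this assay, trimming ethyl to methyl on a saturated chain carbon bound to a saturated ring carbon gives a 1.0-fold higher number from compound 2 to compound 3 (0.01 log units; within the scatter) and so leaves no difference that can be read at this place. Compounds 1 and 2 differ in two places at once and could not show either change alone. Compound 3 also isolates a second change: methyl in place of hydrogen on a saturated chain carbon bound to a carbonyl carbon gives a 1.0-fold higher number from compound 1 to compound 3 (0.02 log units; within the scatter) and likewise stays inside the scatter, so each single change of one carbon, taken by itself, leaves the clearance reading indistinguishable. No measurement here offers an explanation for how close these numbers stay.

On these data alone, both places have so far seen only small carbon groups, so it remains open whether a longer chain such as propyl or butyl would also leave this assay unmoved. An amine or a carboxylic acid at either place, or a bare hydrogen in place of the remaining methyl on the saturated chain carbon, would test these two positions far more sharply than a single carbon does.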